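The compounds below may be only part of what the source reports. "The series", "measured", "known", "first", "only" and "open" are said of these compounds alone.

Measured so far:
Compound 1, `Cc1occc1-c1nnc2sc(-c3ccnc(Cl)c3)nn12`, gives 24.1%.
Compound 2, `COc1ccc(Cl)c(-c2nnc3sc(Cc4c[nH]c5ccc(OC)cc45)nn23)c1`, gives 21.4%.
Compound 3, `COc1ccc2[nH]cc(Cc3nn4c(-c5ccoc5C)nnc4s3)c2c1`, gives 26.1%.

All three numbers come from a functional assay on the whole organism (strain Wistar Albino) for inhibition, with Rattus norvegicus as the target, read by paw edema, with a stated time of 3 h, at a dose of 20 mg/kg; a lower number here means less inhibition, a higher number more inhibition at the dose given (going by the name of the read-out). Compound 3 has the highest of the three numbers, but its gap to compound 1 and its gap to compound 2 are both within the scatter, so the three compounds cannot be told apart. Among the measured compounds shown here, the only measured step, a number 4.7 percentage points higher from compound 2 to compound 3 (within the scatter), exchanges one aromatic group for another and also lies within the scatter. Compound 4, `COc1ccc2[nH]c(C)c(Cc3nn4c(-c5ccoc5C)nnc4s3)c2c1`, differs from compound 3 by methyl in place of hydrogen on an aromatic carbon. For the measured compounds named here, no measured step involves a change of this kind, so nothing here points to a move in either direction. In this assay the step is therefore expected to be a number 0.1 percentage points lower from compound 3 to compound 4 (within the scatter), none beyond the scatter. Compound 4 is estimated at 26%, with a likely range from 15% to 37%.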

Compound 4, a percentage reported as inhibition, in the whole organism at one dose (the size of the read-out at that dose, not a potency): 29.4%
For compound 4 the middle estimate is 3.4 percentage points below the measured one; low and high end bracket the measured number.
By their numbers in this assay, from the lowest: compounds 2, 1, 3 and 4 (each within the scatter of the next).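

Methyl in place of hydrogen on this aromatic carbon, next to the ring nitrogen and next to the ring atom that bears a large group, gives in this assay a number 3.3 percentage points higher from compound 3 to compound 4 (within the scatter). Among the compounds shown here, this is the first look at this position, and the added methyl brings no change that can be told from the scatter. Nothing measured here bears on the reason for this result.

Going by these compounds, whether an ethyl chain, an amine or a carboxylic acid on this carbon would give a step beyond the scatter remains open.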